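Turning one stereocentre of compound 3

A few compounds are considered here, and "the series" means these few. Any claim that something is new, unique, unknown or untested is made for them only; others in the source may bear on it.

In an in vitro ADME assay on microsomes from liver (Homo sapiens) for metabolic stability (on this read-out lower numbers stand for slow clearance and higher numbers for fast clearance), compound 3 (`Cc1oc(-c2ccccc2)nc1CN1CCC[C@@H](C(=O)NC[C@@H]2CCCO2)C1`) gives 69.1 mL.min-1.g-1 as its reading. Compound 2 (`Cc1oc(-c2ccccc2)nc1CN1CCC[C@@H](C(=O)NCc2cccc(N)n2)C1`) gives 49 mL.min-1.g-1 on the same read-out, within the scatter of compound 3. Compound 1 (`COC[C@@H]1C[C@@H](C(=O)NC[C@H]2CCCO2)CN(Cc2nc(-c3ccccc3)oc2C)C1`) gives 233 mL.min-1.g-1 as the highest number of the three, beyond the scatter of compound 3. Compound 4 (`Cc1oc(-c2ccccc2)nc1CN1CCC[C@@H](C(=O)NC[C@H]2CCCO2)C1`) relates to compound 3 as follows: the two compounds have the same atoms and bonds and differ only in configuration as drawn: 1 of 2 stereo elements differ; a stereocentre at a saturated ring carbon is drawn S in compound 3 and R in compound 4 (no group leaves or enters).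

For the measured compounds named here, the only measured step that bears on this is a 1.4-fold higher number from compound 2 to compound 3 (0.15 log units; within the scatter) and it puts oxolan-2-yl in place of 6-aminopyridin-2-yl on a saturated chain carbon bound to an amide-type nitrogen. That step stays within the scatter, but it changes a group and not a configuration. Going by the values given here, no measured pair isolates this stereocentre, and no single-place step joins compound 1 to compound 3. The data therefore offer no reason to expect a shift beyond the scatter in this assay in either direction, and the value of compound 3 at 69.1 mL.min-1.g-1 serves as the anchor. The expected step is a 1.0-fold higher number from compound 3 to compound 4 (0.01 log units; within the scatter) and this estimate lies inside the scatter. Compound 4 is estimated at 70 mL.min-1.g-1 with an expected range from 35 mL.min-1.g-1 to 140 mL.min-1.g-1 for the reading still to come.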

Compound 4, intrinsic clearance in microsomes: 84 mL.min-1.g-1
Compound 4: the middle estimate sits 1.2-fold (0.08 log units) below what was measured, and the stated range covers the measured number.
By their numbers in this assay, from the lowest: compounds 2, 3 and 4 (each within the scatter of the next); then compound 1.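

In this assay the stereocentre at the saturated ring carbon now has a measured step of its own in a 1.2-fold higher number from compound 3 to compound 4 (0.08 log units; within the scatter) and so turning it from S to R leaves the reading within the scatter, a comparison that can be read as one of configuration alone because of a single fact: the fact that compounds 3 and 4 differ only in the configuration as drawn. The exchange of 6-aminopyridin-2-yl for oxolan-2-yl also stays within the scatter with the R configuration in a 1.7-fold higher number from compound 2 to compound 4 (0.23 log units; within the scatter) as it did with the S configuration. For the compounds shown here, the clearest change lies elsewhere on the molecule, since the first single-place link of this kind gives a 2.8-fold lower number from compound 1 to compound 4 (0.44 log units; beyond the scatter) with hydrogen in place of methoxymethyl on a saturated ring carbon, the only new step beyond the scatter.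

On these data alone, what remains open is whether the methoxymethyl step would have the same size with the S configuration at the oxolan-2-yl carbon, and whether the other drawn stereocentre matters in this assay. Nor do these compounds show whether a hydroxymethyl group or an ethyl group on that saturated ring carbon would read closer to compound 4 or to compound 1.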